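Replacing fluoro with methyl on a weakly cytotoxic compound

A few compounds are considered here, and "the series" means these few. Any claim that something is new, unique, unknown or untested is made for them only; others in the source may bear on it.

In a functional assay on MDA-MB-231 cells (Homo sapiens) for cytotoxicity, read by MTT assay, with a stated time of 48 h (on this read-out lower numbers stand for stronger inhibition and higher numbers for weaker inhibition), compound 2 `CCn1c(/C=C2/C(=O)Nc3ccc(F)cc32)nc2ccccc21` returns only > 50000 nM as a limit of the assay and not a number. Compound 3 `CC(C)n1c(/C=C2/C(=O)Nc3ccc(F)cc32)nc2ccccc21` gives 22700 nM on this read-out, and compound 1 `CC(C)n1c(/C=C2/C(=O)Nc3ccc(Br)cc32)nc2ccccc21` gives 3260 nM on it.

Compound 4 `CCn1c(/C=C2/C(=O)Nc3ccc(C)cc32)nc2ccccc21` differs from compound 2 by methyl in place of fluoro on an aromatic carbon and keeps the rest of the structure. Going by the values given here, two measured steps bear on this change. The closer one alters the same aromatic carbon: a 7.0-fold higher number from compound 1 to compound 3 (0.84 log units; beyond the scatter) comes with fluoro in place of bromo, so fluoro gave the higher number of those two groups. The other, an at least 2.2-fold lower number from compound 2 to compound 3 (0.34 log units; beyond the scatter), comes with methyl in place of hydrogen on the chain, and compound 4 keeps the chain of compound 2. Among the compounds with values here, no measured compound carries methyl on the aromatic carbon, so only a modest fall is expected in this assay. The expected change is an at least 2.0-fold lower number from compound 2 to compound 4 (0.30 log units; that floor lies within the scatter). A limit of the assay remains possible for compound 4. For compound 4 the estimated value is 25000 nM within an expected range of 8000 nM to 50000 nM.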

Compound 4, half-maximal inhibitory concentration: 40600 nM
For compound 4 the middle estimate is 1.6-fold (0.21 log units) below the measured one, and the stated range covers the measured number.
By their numbers in this assay, from the lowest: compound 1; then compounds 3 and 4 (each within the scatter of the next). At a limit, above all of these: compound 2.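

Going by these compounds alone, until this result, the aromatic carbon had been read only with bromo and fluoro, and the chain of compound 2 had given no number at all. In this assay, methyl in place of fluoro comes with an at least 1.2-fold lower number from compound 2 to compound 4 (0.09 log units; that floor lies within the scatter), so this chain can return a measured number when methyl sits on that carbon. Going by these compounds, the true size of the step stays unknown because compound 2 sits at a limit, and the floor alone does not separate methyl from fluoro: the limit of > 50000 nM in this assay, at which 1 of the 4 values shown sits.

The compounds shown leave open how chloro, methoxy or an amine on this aromatic carbon would read in this assay. They also leave open whether methyl there would hold its reading with a longer chain on the aromatic nitrogen.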